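This account rests on a few compounds, and the source may have more. Where it says the series, first, only, none or still open, it means among the compounds named here.

Compound 1 `O=C(Nc1cc(Sc2ncn[nH]2)c(O)c2ccccc12)c1cccc([N+](=O)[O-])c1` gives 29.3% in an assay on isolated protein for inhibition of RAC-alpha serine/threonine-protein kinase (Homo sapiens), read by fluorescence, with a stated time of 30 min, tested at 10 uM; on this read-out higher numbers stand for more inhibition at the one concentration tested (going by the name of the read-out) and lower numbers for less inhibition.
Compound 2 `COc1cccc(C(=O)Nc2cc(Sc3ncn[nH]3)c(O)c3ccccc23)c1` gives 19.4% in this assay.

Compound 2 holds the lower of the two numbers, with compound 1 nearest, and the step of a number 9.9 percentage points lower from compound 1 to compound 2 (within the scatter) lies within the scatter, so the two cannot be told apart. Compound 3 `Cc1cccc(C(=O)Nc2cc(Sc3ncn[nH]3)c(O)c3ccccc23)c1` differs from compound 2 by methyl in place of methoxy on an aromatic carbon. Among the measured compounds shown here, no measured step exchanges these two groups; the one step known concerns another group and stayed within the scatter. Compound 3 is therefore expected to move by a number 2.6 percentage points higher from compound 2 to compound 3 (within the scatter) at most, no step beyond the scatter. Compound 3 is estimated at 22%, between 8% and 38%.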

Compound 3, a percentage reported as inhibition, at one concentration (the size of the read-out at that concentration, not a potency): 20.2%
Compound 3: middle estimate off by 1.8 percentage points, on the high side; measured number inside the range.
By their numbers in this assay, from the lowest: compounds 2, 3 and 1 (each within the scatter of the next).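

With methyl in place of methoxy on an aromatic carbon meta to a large group, this assay shows a number 0.8 percentage points higher from compound 2 to compound 3 (within the scatter) and so cannot tell a group with a hydrogen-bond acceptor from one without at this place. Methyl in place of nitro gives a number 9.1 percentage points lower from compound 1 to compound 3 (within the scatter) so all three groups now lie within the scatter of one another, a pairing that the earlier step alone could not cover. Nothing available explains this result. As far as these compounds go, whether an amine, a carboxylic acid or a longer chain at this place would step beyond the scatter remains open.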